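A few compounds are considered here, and "the series" means these few. Any claim that something is new, unique, unknown or untested is made for them only; others in the source may bear on it.

The measured compounds:
Compound 1, `O=C(/C=C/c1ccc2c(c1)C(=O)CC1(CNC1)O2)NO`: 2580 nM
Compound 2, `CN1CC2(CC(=O)c3cc(/C=C/C(=O)NO)ccc3O2)C1`: 168 nM

Going by the values given here, compound 2 stands lowest of the two numbers in a functional assay on K562 cells (Homo sapiens) for antiproliferative activity, read by luminescence, with a stated time of 72 h; on this read-out lower numbers stand for stronger inhibition and higher numbers for weaker inhibition; its only neighbour, compound 1, gives 2580 nM, a higher number, and the single measured step, a 15-fold lower number from compound 1 to compound 2 (1.19 log units; beyond the scatter), is large and beyond the scatter. Compound 3, `CC(=O)N1CC2(CC(=O)c3cc(/C=C/C(=O)NO)ccc3O2)C1`, is not yet measured in this assay. It differs from compound 2 by acetyl in place of methyl on an amine nitrogen in a ring. Among the compounds with values here, the only step that bears on this change is the one from compound 1 to compound 2, at the same nitrogen but exchanging hydrogen for methyl; no measured step replaces methyl with acetyl, so the direction of the new step is not fixed by the data. Because the earlier step of a 15-fold lower number from compound 1 to compound 2 (1.19 log units; beyond the scatter) was large, a change at this nitrogen is expected to shift the number again, most likely upward, with wide uncertainty. Compound 3 is estimated at 500 nM, ranging from 150 nM to 2000 nM, an expected step of a 3.0-fold higher number from compound 2 to compound 3 (0.47 log units; beyond the scatter).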

Compound 3, half-maximal inhibitory concentration: 15100 nM
Compound 3: the middle estimate sits 30-fold (1.48 log units) below what was measured, outside the stated range (above it).
By their numbers in this assay, from the lowest: compound 2; then compound 1; then compound 3.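

At the amine nitrogen in a ring, the substituent matters in both directions in this assay: replacing methyl with acetyl gives a step larger than the earlier gain from methyl (a 90-fold higher number from compound 2 to compound 3 (1.95 log units; beyond the scatter)). Acetyl also ranks behind the bare hydrogen (a 5.9-fold higher number from compound 1 to compound 3 (0.77 log units; beyond the scatter)), a more modest step, so the order here is methyl, then hydrogen, then acetyl, and does not follow the number of heavy atoms added at this nitrogen. No measurement offered here accounts for this reversal.

The compounds shown leave open whether the carbonyl of the acetyl or its added carbons drive the loss, a question that an ethyl group on the same nitrogen would help to separate. From the compounds shown here alone, how a longer alkyl chain or a methanesulfonyl group would fall at this position also remains open.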